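This account rests on a few compounds, and the source may have more. Where it says the series, first, only, none or still open, it means among the compounds named here.

Of the compounds shown here, three have been measured in a functional assay (MiaPaCa cells, Homo sapiens) for inhibition, read by sulforhodamine B assay, with a stated time of 48 h (a lower number here means a stronger inhibitor of growth, a higher number a weaker inhibitor of growth), and a fourth awaits its number. Compound 1 `O=C(N/N=C/C1=C(Cl)c2ccccc2CCC1)c1cccc(Cl)c1` gives 78400 nM in this assay. Compound 2 `Nc1ccccc1C(=O)N/N=C/C1=C(Cl)c2ccccc2CCC1` gives 65100 nM in this assay. Compound 3 `Cc1cc2c(cc1C)C(Cl)=C(/C=N/NC(=O)c1cccc(Cl)c1)CCC2` gives 33600 nM in this assay, the lowest of the three numbers, though its gap to compound 2 lies within the scatter and only its gap to compound 1 lies beyond it. Compound 4 `Cc1cc2c(cc1C)C(Cl)=C(/C=N/NC(=O)c1ccccc1N)CCC2` is the one not yet measured.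

The change from compound 1 to compound 2 is 2-aminophenyl in place of 3-chlorophenyl on a carbonyl carbon and it made a step of a 1.2-fold lower number from compound 1 to compound 2 (0.08 log units; within the scatter). Compound 4 arises from compound 3 by the same change, (2-aminophenyl in place of 3-chlorophenyl on a carbonyl carbon), and since the surroundings of the place agree word for word, this is the same change in the same setting. How the core of compound 3 differs from the core of compound 1 is not broken down here.

Because the earlier step of a 1.2-fold lower number from compound 1 to compound 2 (0.08 log units; within the scatter) stayed within the scatter, a step of about the same small size is expected from compound 3 to compound 4. Resting on that earlier step, the expected step is a 1.2-fold lower number from compound 3 to compound 4 (0.08 log units; within the scatter). Compound 4 is therefore estimated at 28000 nM, with a likely range from 12000 nM to 65000 nM.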

Compound 4, concentration for 50% growth inhibition: 810 nM
Compound 4: middle estimate off by 35-fold (1.54 log units), on the high side; measured number outside the range, below it.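

In this assay, putting 2-aminophenyl in place of 3-chlorophenyl on a carbonyl carbon gave a 41-fold lower number from compound 3 to compound 4 (1.62 log units; beyond the scatter), so on the core of compound 3 this single swap of one ring substituent pattern for another goes with a large gain in growth inhibition. The result of the swap therefore depends on the core that carries it, and a step measured on one core cannot simply be copied to another in this series, as the two pairs show when set side by side: the same change on two cores in this assay, a 1.2-fold lower number (0.08 log units; within the scatter) from compound 1 to compound 2 and a 41-fold lower number (1.62 log units; beyond the scatter) from compound 3 to compound 4, 34-fold (1.54 log units) apart, beyond the scatter of two such steps. What this does not show is which feature of the core of compound 3 makes the difference or how it does so, and two pairs of compounds are too few to give a rule for any further core.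

The compounds shown leave open whether the large step belongs to the amine itself, which a hydroxyl or a methoxy group in its place on the core of compound 3 could test. They also leave open which part of the difference between the two cores is needed for the step to appear, and whether it would appear on any other core.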